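This account rests on a few compounds, and the source may have more. Where it says the series, first, only, none or still open, it means among the compounds named here.

Three compounds have been measured so far in an assay for inhibition of acid-sensing ion channel 3 (Homo sapiens), read by patch clamp, tested at 1 uM; a higher number here means more inhibition at the concentration tested (going by the name of the read-out), a lower number less inhibition:

Compound 1, `NC(N)=NC(=O)c1nc(Cl)c(NCc2ccccc2Cl)nc1N`, gives 31%.
Compound 2, `CCCNc1nc(N)c(C(=O)N=C(N)N)nc1Cl`, gives 24%.
Compound 3, `NC(N)=NC(=O)c1nc(Cl)c(N2CCCC2)nc1N`, gives 12%.

Compound 3 stands lowest of the three numbers. Its nearest neighbour is compound 2, and the gap between them is beyond the scatter; the gap to compound 1 is larger still. The step of a number 7 percentage points lower from compound 1 to compound 2 (within the scatter), ethyl in place of 2-chlorophenyl on a saturated chain carbon bound to a nitrogen on an aromatic ring, lies within the scatter. The step of a number 12 percentage points lower from compound 2 to compound 3 (beyond the scatter), pyrrolidin-1-yl in place of propylamino on an aromatic carbon, is modest but beyond the scatter.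

Compound 4, `COc1nc(N)c(C(=O)N=C(N)N)nc1Cl`, has not yet been measured. It differs from compound 3 in one place: methoxy in place of pyrrolidin-1-yl on an aromatic carbon. Within the data shown here, only the step from compound 2 to compound 3 touches the same aromatic carbon, and it moved the read-out downward by a modest amount; no measured step shows a methoxy group at that position. With compound 3 already low, the step of a number 2 percentage points lower from compound 3 to compound 4 (within the scatter) is expected to stay within the scatter. Compound 4 is therefore estimated at 10%, with a range from 0% to 25%.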

Compound 4, a percentage reported as inhibition, at one concentration (the size of the read-out at that concentration, not a potency): 21%
The estimate for compound 4 lay 11 percentage points below the measured number; the measured number falls inside the stated range.
By their numbers in this assay, from the lowest: compounds 3, 4, 2 and 1 (each within the scatter of the next, the first and the last beyond it).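

At the aromatic carbon next to the ring nitrogen, this assay now has a third group to compare, and exchanging the ring-bearing pyrrolidin-1-yl for methoxy, which has no ring and fewer heavy atoms, gives a number 9 percentage points higher from compound 3 to compound 4 (within the scatter) as the step. Exchanging propylamino for that same methoxy gives a number 3 percentage points lower from compound 2 to compound 4 (within the scatter) as the step, so compound 4 lies within the scatter of both neighbours even though those two are printed as beyond the scatter of each other. The earlier single step at this carbon could be read only as a drop on going to the ring, whereas the new pair shows that an oxygen-linked group of just two heavy atoms can take the place of either nitrogen-linked group without a step beyond the scatter.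

Still open is how an ethoxy group, a hydroxyl, a morpholine ring or a longer chain on the oxygen would read at this carbon, and a single tested concentration gives no potency for any of these compounds. Nothing available here accounts for why these groups read as they do.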